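This account rests on a few compounds, and the source may have more. Where it says the series, first, only, none or still open, it means among the compounds named here.

Compound 1 `O=C(Nc1nn(-c2ccccc2)c(=O)c2ccccc12)c1ccccc1` and compound 2 `O=C(Nc1ccc(Cl)cc1)Nc1nn(-c2ccccc2)c(=O)c2ccccc12` share one core and differ only at the carbonyl carbon, where compound 2 carries a (4-chlorophenyl)amino group in place of phenyl. In an assay on CHO cells for displacement of a labelled ligand from adenosine receptor A1 (Homo sapiens), tested at 10 uM (a lower number here means less inhibition, a higher number more inhibition at the concentration tested (going by the name of the read-out)), compound 1 gives 44%, whereas compound 2 gives 10%, so the step of a number 34 percentage points lower from compound 1 to compound 2 (beyond the scatter) is the only measured one and it is large. Among the measured compounds shown here, compound 2 therefore stands lowest of the two numbers, with compound 1 as its sole neighbour, higher by a margin beyond the scatter.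

Compound 3 `O=C(Nc1ccccc1)Nc1nn(-c2ccccc2)c(=O)c2ccccc12` keeps the whole (4-chlorophenyl)amino side of compound 2 but drops the chloro: hydrogen in place of chloro on an aromatic carbon. For the measured compounds named here, no measured step touches this spot; the single step in hand replaces the entire group on the carbonyl carbon, so it gives no direct guide to removing one chloro from an otherwise unchanged group. Without such a guide, the expectation is a step of a number 5 percentage points higher from compound 2 to compound 3 (within the scatter) that may well stay within the scatter. In this assay compound 3 is estimated at 15%, with a range from 0% to 40%.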

Compound 3, a percentage reported as inhibition, at one concentration (the size of the read-out at that concentration, not a potency): 44%
Compound 3: middle estimate off by 29 percentage points, on the low side; measured number outside the range, above it.
By their numbers in this assay, from the lowest: compound 2; then compounds 1 and 3 (each within the scatter of the next).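

In this assay, hydrogen in place of chloro on the aromatic carbon gives a number 34 percentage points higher from compound 2 to compound 3 (beyond the scatter), so changing a single atom at this spot, para to a large group, is enough for a large step. Anilino in place of phenyl on the carbonyl carbon gives no change at the digits printed from compound 1 to compound 3 (within the scatter), which shows that the large drop seen earlier with (4-chlorophenyl)amino does not appear once the chloro is absent: in this small set, the added amino link alone leaves the number where it was, and the chloro on the ring goes with the low number. Nothing at hand explains why this one atom matters so much.

As far as these compounds go, whether a fluoro, a methyl or a methoxy group on the same carbon would behave like the chloro or like hydrogen stays open, as does the effect of placing the chloro on another carbon of that ring. Each number is also an inhibition at a single concentration, so how the potencies of these compounds compare remains open too.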